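Cytotoxicity series: nitro to trifluoromethyl swap on the aryl ring

This account rests on a few compounds, and the source may have more. Where it says the series, first, only, none or still open, it means among the compounds named here.

Measured compounds:
compound 1 `O=[N+]([O-])c1ccc(NC(CO)CO)c([N+](=O)[O-])c1` — > 100000 nM
compound 2 `O=[N+]([O-])c1cc(C(F)(F)F)ccc1NC(CO)CO` — > 100000 nM

In a functional assay on SH-SY5Y cells (Homo sapiens) for cytotoxicity (a higher number here means a weaker inhibitor, a lower number a stronger inhibitor), compound 1 gives > 100000 nM, which is a limit of the assay and not a number. Compound 2 gives > 100000 nM in this assay, again a limit and not a number. For the measured compounds named here, the only measured step, a step that the two limits leave unreadable from compound 1 to compound 2, therefore cannot be sized; both values sit at the limit of > 100000 nM in this assay, at which 2 of the 2 values shown sit, and this is all the measured pair shows.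

The next compound, compound 3 `O=[N+]([O-])c1ccc(NC(CO)CO)c(C(F)(F)F)c1`, is not yet measured. It differs from compound 1 by trifluoromethyl in place of nitro on an aromatic carbon, a change on an aromatic carbon. This change touches the same kind of group as the measured step, yet that step remains unreadable, so no direction or size can be taken from it. With both measured compounds at the limit, compound 3 is expected to give a value near 100000 nM, within 30000 nM to 300000 nM, most likely reported as a limit; the step of a number no higher from compound 1 to compound 3 (the limit leaves the size open) is estimated as none beyond the scatter.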

Compound 3, half-maximal inhibitory concentration: > 100000 nM
Compound 3 gave a limit, no number; the forecaster's own chance of this, stated with the estimate: 85%; the middle value sits exactly at the limit.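

No step can be read from compound 1 to compound 3, because in this assay both give a limit and not a number: the limit of > 100000 nM in this assay, at which 3 of the 3 values shown sit.

The compounds shown leave open whether trifluoromethyl in place of nitro on an aromatic carbon changes the half-maximal inhibitory concentration at all.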